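Swapping the aryl group on a thiosemicarbazone of a terpene alcohol

The source may report more compounds than this note shows. Statements on the series, on what has been measured and on what is new or still open speak of the compounds shown alone.

The measured compounds:
compound 1, `CC1=CC[C@@H]([C@@](C)(O)CCCC(C)(C)NC=S)CC1`, 9960 nM
compound 2, `CC1=CC[C@@H]([C@@](C)(O)CCCC(C)(C)NC(=S)NN)CC1`, 18500 nM
compound 3, `COc1ccc(/C=N\NC(=S)NC(C)(C)CCC[C@](C)(O)[C@@H]2CC=C(C)CC2)cc1`, 7420 nM

All three were tested in a functional assay on UACC-62 cells (Homo sapiens) for cytotoxicity, read by sulforhodamine B assay; on this read-out lower numbers stand for stronger inhibition of growth and higher numbers for weaker inhibition of growth. Compound 3 has the lowest of the three numbers; compound 1 lies within the scatter of it, while compound 2 sits beyond it. The two measured steps are a 1.9-fold higher number from compound 1 to compound 2 (0.27 log units; within the scatter) and a 2.5-fold lower number from compound 2 to compound 3 (0.40 log units; beyond the scatter), the second being the only one beyond the scatter, and it joined the aryl-bearing part to the shared core.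

Compound 4, `CC1=CC[C@@H]([C@@](C)(O)CCCC(C)(C)NC(=S)N/N=C\c2ccccc2[N+](=O)[O-])CC1`, keeps that part and changes only the aryl group: 2-nitrophenyl in place of 4-methoxyphenyl on a carbon with a double bond to nitrogen. Among the measured compounds shown here, no measured step touches the aryl group itself, so neither step bears directly on this change; the one that added the aryl part, from compound 2 to compound 3, was modest. With nothing to point in either direction, the expected step of a 1.0-fold lower number from compound 3 to compound 4 (0.00 log units; within the scatter) is taken to be none beyond the scatter. Compound 4 is therefore estimated at 7400 nM in this assay, with a range from 3000 nM to 18000 nM.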

Compound 4, concentration for 50% growth inhibition: 6050 nM
Compound 4: middle estimate off by 1.2-fold (0.09 log units), on the high side; the measured number falls inside the stated range.
By their numbers in this assay, from the lowest: compounds 4, 3, 1 and 2 (each within the scatter of the next, the first and the last beyond it).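

Among the compounds shown here, exchanging 4-methoxyphenyl for 2-nitrophenyl on a carbon with a double bond to nitrogen gives a 1.2-fold lower number from compound 3 to compound 4 (0.09 log units; within the scatter) in this assay and is the first direct test of the aryl group in this set. The two groups differ in their atoms and in their counts of hydrogen-bond acceptors, yet compound 3 and compound 4 remain within the scatter of each other, so this single exchange does not separate them on this read-out. No supporting evidence is available to explain this result.

For the compounds shown here, this is only one pair, so it cannot show whether the same would hold for other aryl groups. From the compounds shown here alone, what an amine or a carboxylic acid on the aryl group would do at this place, or a simple alkyl chain in place of the aryl group, remains open.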